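Notes on compound 4 in the anilide series

This account rests on a few compounds, and the source may have more. Where it says the series, first, only, none or still open, it means among the compounds named here.

Among the compounds with values here, compound 3 `COc1ccc(C(=O)Nc2cccc(NC(=O)COc3ccc4c(=O)ccoc4c3)c2)cc1` gives 7 nM in an assay on isolated protein for inhibition of Rho-associated protein kinase 2 (Homo sapiens), read by scintillation counting, radiometric assay and 33P incorporation, with a stated time of 40 min, in the presence of a further agent that is not named here (a lower number here means a stronger inhibitor, a higher number a weaker inhibitor), the lowest of the three numbers measured so far. Compound 1 `CC(=O)Nc1cccc(NC(=O)COc2ccc3c(=O)ccoc3c2)c1` gives 136 nM, and compound 2 `CC(C)(C)c1ccc(C(=O)Nc2cccc(NC(=O)COc3ccc4c(=O)ccoc4c3)c2)cc1` gives 34 nM. The measured steps run a 19-fold lower number from compound 1 to compound 3 (1.29 log units; beyond the scatter), a 4.0-fold lower number from compound 1 to compound 2 (0.60 log units; beyond the scatter) and a 4.9-fold lower number from compound 2 to compound 3 (0.69 log units; beyond the scatter). Compound 4 `CCOc1ccc(C(=O)Nc2cccc(NC(=O)COc3ccc4c(=O)ccoc4c3)c2)cc1` differs from compound 3 by methyl in place of hydrogen on a saturated chain carbon bound to an oxygen on an aromatic ring. Within the data shown here, no measured step touches this chain directly; the closest comparison is the modest step from tert-butyl to methoxy, which shows that the group on that aromatic carbon moves the number, though that swap is a far larger change than methyl to ethyl. The expectation for compound 4 is therefore a 1.4-fold higher number from compound 3 to compound 4 (0.15 log units; within the scatter), within the scatter or only slightly beyond it. Compound 4 is estimated at 10 nM, with a range of 4 nM to 25 nM.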

Compound 4, half-maximal inhibitory concentration: 9 nM
Beside the measured number, compound 4's estimate is 1.1-fold (0.05 log units) above it, and the stated range covers the measured number.
By their numbers in this assay, from the lowest: compounds 3 and 4 (each within the scatter of the next); then compound 2; then compound 1.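

Lengthening methoxy to ethoxy gives a 1.3-fold higher number from compound 3 to compound 4 (0.11 log units; within the scatter) and so no readable change at this saturated chain carbon bound to an oxygen on an aromatic ring. The ethoxy compound also stays clear of the two weaker compounds, with a 3.8-fold lower number from compound 2 to compound 4 (0.58 log units; beyond the scatter) and with a 15-fold lower number from compound 1 to compound 4 (1.18 log units; beyond the scatter) for 4-ethoxyphenyl in place of methyl on the carbonyl carbon. No measurement at hand explains why the added methyl leaves the number in place.

Still open, on these data alone, is whether a propoxy chain, or a chain ending in an amine or a carboxylic acid, would hold the number reached with ethoxy.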